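Swapping a Sec-Butyl for a Pyrazolyl on the Amide Nitrogen

The source may report more compounds than this note shows. Statements on the series, on what has been measured and on what is new or still open speak of the compounds shown alone.

Of the compounds shown here, three built on a shared core have been tested in an assay on HEK293 cells for agonist activity at transient receptor potential cation channel subfamily M member 8 (Homo sapiens), read by fluorescence and calcium flux, with a stated time of 15 min; a higher number here means that more compound is needed for the effect, a lower number that less compound is needed. Compound 1 `CCc1ccc(OCC(=O)N(CC)Cc2cccs2)cc1` gives 67 nM, and compound 3 `CCN(Cc1cccs1)C(=O)COc1ccc2c(c1)COC2` gives 61 nM. Compound 2 `CCC(C)N(Cc1cccs1)C(=O)COc1ccc(C)cc1` gives 2000 nM, the highest number of the three; its gaps to compound 1 and to compound 3 both lie well beyond the usual scatter, so compound 2 is the weakest agonist of the set.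

Compound 4 `Cc1ccc(OCC(=O)N(Cc2cccs2)c2c(C)n[nH]c2C)cc1` has not been measured. It differs from compound 2 in one place: 3,5-dimethyl-1H-pyrazol-4-yl in place of sec-butyl on an amide-type nitrogen. Going by the values given here, no measured pair in this set shows what such a ring does at that position, so the direction of the change rests on the weak starting point alone. Because compound 2 gives 2000 nM, there is more room for the number to fall than to rise. The step of a 2.5-fold lower number from compound 2 to compound 4 (0.40 log units; beyond the scatter) is expected to be a moderate lowering, with wide uncertainty. For compound 4 the estimate is 800 nM, expected to lie between 150 nM and 4000 nM.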

Compound 4, half-maximal effective concentration: 0.3 nM
The estimate for compound 4 lay 2700-fold (3.43 log units) above the measured number; the whole stated range lies above it.
By their numbers in this assay, from the lowest: compound 4; then compounds 3 and 1 (each within the scatter of the next); then compound 2.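

On this amide-type nitrogen, 3,5-dimethyl-1H-pyrazol-4-yl in place of sec-butyl gives a 6700-fold lower number from compound 2 to compound 4 (3.82 log units; beyond the scatter) in this assay. Going by these compounds alone, this is the first change in the set that can be read in one place, and it shows that the group on this nitrogen can move the number enormously. The position accepts an aromatic ring carrying a hydrogen-bond donor and a hydrogen-bond acceptor, none of which sec-butyl has, and the number falls rather than rises. Nothing available here accounts for a fall of this size.

The step changes the ring, the nitrogen atoms and the two methyl groups all at once, leaving open which of these matters. A plain pyrazol-4-yl without the methyl groups, or a phenyl ring, on this nitrogen would begin to separate them.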